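Replacing the isopropoxycarbonyl group of compound 2

The source may hold more compounds than are shown below. What is called first, only, known or untested is meant among the compounds shown, and "the series" means these compounds.

Compound 1 `CCOC(=O)c1ccc(-c2nn(Cc3ccccn3)c3ccccc23)cc1`: 290 nM
Compound 2 `CC(C)OC(=O)c1ccc(-c2nn(Cc3ccccc3)c3ccccc23)cc1`: > 10000 nM

In a functional assay on cells (Platelet, Homo sapiens) for inhibition (on this read-out higher numbers stand for weaker inhibition and lower numbers for stronger inhibition), compound 1 gives a true measured number, 290 nM. Compound 2 stands at the end of the scale: its > 10000 nM is a limit of the assay and not a number.

Compound 3 `CO/N=C\c1ccc(-c2nn(Cc3ccccc3)c3ccccc23)cc1` has not been measured yet. It keeps the core of compound 2 and changes in one place, on an aromatic carbon of a six-membered aromatic ring of carbon only, para to a large group: a group of 4 heavy atoms (2 carbon, 1 nitrogen, 1 oxygen; no ring) in place of a group of 6 heavy atoms (4 carbon, 2 oxygen; no ring), on an aromatic carbon. The isopropoxycarbonyl group leaves, and a group with no common name enters.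

Among the compounds with values here, the data hold no measured step between compounds that differ in one place, so any expectation here is loose. A modest gain in inhibition, meaning a lower number in this assay, is expected, although compound 3 may well stay at the limit. As a step, the expected change is an at least 1.6-fold lower number from compound 2 to compound 3 (0.22 log units; that floor lies within the scatter). For compound 3 the estimated value is 6000 nM, with an expected range from 1500 nM to 15000 nM.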

Compound 3, half-maximal inhibitory concentration: > 10000 nM
Compound 3 gave a limit, no number (the forecaster's own chance of this, stated with the estimate: 45%); at least 1.6-fold (0.22 log units) between middle value and limit.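

Compound 2 and compound 3 both sit at a limit of the scale in this assay, so no step can be read between them, because neither gives a true number: the limit of > 10000 nM in this assay, at which 2 of the 3 values shown sit.

The compounds shown leave open whether replacing the isopropoxycarbonyl group of compound 2 with the group in compound 3 changes inhibition at all, and in which direction.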